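Aryl-to-hydroxypiperidinyl swap on the sulfonyl group, compound 4

The source may report more compounds than this note shows. Statements on the series, on what has been measured and on what is new or still open speak of the compounds shown alone.

Measured so far in a functional assay on A2780 cells (Homo sapiens) for cytotoxicity, read by sulforhodamine B assay, with a stated time of 72 h; on this read-out lower numbers stand for stronger inhibition and higher numbers for weaker inhibition:
compound 1 `O=C(NCc1ccc(S(=O)(=O)c2cccc(C(F)(F)F)c2)cc1)N1Cc2ccncc2C1` — 2.7 nM
compound 2 `CC(C)n1cc(S(=O)(=O)c2ccc(CNC(=O)N3Cc4ccncc4C3)cc2)cn1` — 11 nM
compound 3 `CN1CCC(S(=O)(=O)c2ccc(CNC(=O)N3Cc4ccncc4C3)cc2)CC1` — 99 nM

Compound 1 carries a 3-(trifluoromethyl)phenyl group on the sulfonyl sulfur and gives the lowest number of the three in this assay. The step of a 4.1-fold higher number from compound 1 to compound 2 (0.61 log units; beyond the scatter) and the step of a 37-fold higher number from compound 1 to compound 3 (1.56 log units; beyond the scatter) both run in the same direction, and the step of a 9.0-fold higher number from compound 2 to compound 3 (0.95 log units; beyond the scatter) shows that the saturated 1-methylpiperidin-4-yl group costs most: moving from an aromatic group to a non-aromatic one on the sulfonyl sulfur has so far weakened the series each time it was tried.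

Compound 4 `O=C(NCc1ccc(S(=O)(=O)N2CCC(O)CC2)cc1)N1Cc2ccncc2C1` is the next member. Its change from compound 1: 4-hydroxypiperidin-1-yl in place of 3-(trifluoromethyl)phenyl on a sulfonyl sulfur. The new group is, like that of compound 3, a six-membered non-aromatic ring with a hetero atom, and it also adds a hydrogen-bond donor. Among the compounds with values here, the nearest measured step is the one from compound 1 to compound 3, a large one, and the step from compound 2 to compound 3 points the same way. The expectation for compound 4 is therefore a step of about a 56-fold higher number from compound 1 to compound 4 (1.74 log units; beyond the scatter), toward a higher number, clearly beyond the scatter. Compound 4 is expected to give about 150 nM in this assay, with a range of 40 nM to 600 nM.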

Compound 4, half-maximal inhibitory concentration: 98 nM
For compound 4 the middle estimate is 1.5-fold (0.18 log units) above the measured one, within the range that was stated.
By their numbers in this assay, from the lowest: compound 1; then compound 2; then compounds 4 and 3 (each within the scatter of the next).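

In this assay, a second non-aromatic six-membered ring shows that the result of compound 3 is not confined to one group: a 1.0-fold lower number from compound 3 to compound 4 (0.00 log units; within the scatter), so 4-hydroxypiperidin-1-yl and 1-methylpiperidin-4-yl cannot be told apart at this position. The aromatic groups remain separate from this pair, with a 36-fold higher number from compound 1 to compound 4 (1.56 log units; beyond the scatter) and an 8.9-fold higher number from compound 2 to compound 4 (0.95 log units; beyond the scatter), so among the four compounds both aromatic groups give lower numbers than both non-aromatic ones, and none goes against this pattern. Nothing available gives a measured reason for these steps or for the match between compounds 3 and 4.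

Open, as far as these compounds go, is whether the gap follows the aromatic ring itself or the particular substituents on it, which an unsubstituted phenyl, a 3-chlorophenyl or a 1-methyl-1H-pyrazol-4-yl group on the sulfonyl sulfur would help to separate. Also open, from the compounds shown here alone, is how far the non-aromatic result extends, since a morpholin-4-yl group, an unsubstituted piperidin-1-yl group or a piperidine ring carrying a primary amine or a carboxylic acid could either stay with compounds 3 and 4 or depart from them.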